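Bromo sulfonamide series: dimethylamino to diethylamino

This account rests on a few compounds, and the source may have more. Where it says the series, first, only, none or still open, it means among the compounds named here.

Measured in a functional assay on PANC-1 cells (Homo sapiens) for antiproliferative activity, read by MTT assay, with a stated time of 48 h; a higher number here means a weaker inhibitor, a lower number a stronger inhibitor
- compound 1 (`Cc1c(C(=O)N2CCCC(C)C2)oc2ccc(N(Cc3ccc(Br)cc3)S(=O)(=O)c3ccc(Br)cc3)cc12`), 26200 nM
- compound 2 (`CN(C)CCNC(=O)c1nc2cc(N(Cc3ccc(Br)cc3)S(=O)(=O)c3ccc(Br)cc3)ccc2o1`), 13600 nM

In this assay compound 2 stands within the scatter of compound 1, and the two differ in more than one place. For the measured compounds named here, no measured pair shows the change at hand. Compound 3 (`CCN(CC)CCNC(=O)c1nc2cc(N(Cc3ccc(Br)cc3)S(=O)(=O)c3ccc(Br)cc3)ccc2o1`) has diethylamino in place of dimethylamino on a saturated chain carbon, two bonds along the chain from an amide-type nitrogen. The estimated step (a 1.1-fold lower number from compound 2 to compound 3 (0.05 log units; within the scatter)) is expected to stay within the scatter, in neither direction. For compound 3 the expected value is 12000 nM, with an estimated range from 5500 nM to 26000 nM in this assay.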

Compound 3, half-maximal inhibitory concentration: 12600 nM
The estimate for compound 3 lay 1.1-fold (0.02 log units) below the measured number, within the range that was stated.
By their numbers in this assay, from the lowest: compounds 3, 2 and 1 (each within the scatter of the next, the first and the last beyond it).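

In this assay, diethylamino in place of dimethylamino on a saturated chain carbon, two bonds along the chain from an amide-type nitrogen, gives a 1.1-fold lower number from compound 2 to compound 3 (0.03 log units; within the scatter). For the compounds shown here, this is the first comparison that isolates a single change, and at this position the larger amine stays within the scatter. No measurement at hand bears on this result.

As far as these compounds go, whether a morpholine or pyrrolidine ring in place of diethylamino, or a longer chain to the amine, would also stay within the scatter remains open. So does the outcome of this change on other cores, such as the core of compound 1.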